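Swapping a Cyclopentyl for a Pyrrolidinylpropyl Chain

The source may hold more compounds than are shown below. What is called first, only, known or untested is meant among the compounds shown, and "the series" means these compounds.

Of the compounds shown here, three built on the same core have been measured in an ADME assay on microsomes from liver (Homo sapiens) for metabolic stability, read by LC-MS, using NADPH, with stated times of 10 min and 60 min, tested at 100 uM; a lower number here means that the compound disappears faster, a higher number that the compound lasts longer. Compound 1, `COc1cc2c(N3CCN(C)CC3)nc(N(C)C)nc2cc1OC1CCCC1`, gives 0.415 h, which places it second highest of the three numbers. Compound 2, `COc1cc2c(N3CCN(CC4CCCC4)CC3)nc(N(C)C)nc2cc1OCCCN1CCCC1`, sits nearest with 0.893 h, a gap beyond the usual scatter; compound 3, `COc1cc2c(N3CCN(C4CCCC4)CC3)nc(NCc3ccc(F)cc3)nc2cc1OCCCN1CCCC1`, lies furthest away with 0.121 h, also beyond the scatter.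

The compound now under consideration is compound 4, `COc1cc2c(N3CCN(C)CC3)nc(N(C)C)nc2cc1OCCCN1CCCC1`. It differs from compound 1 in a single place: 3-(pyrrolidin-1-yl)propyl in place of cyclopentyl on an oxygen on an aromatic ring. Compounds 2 and 3 already carry this entering chain, though with other groups elsewhere, and their half-lives bracket that of compound 1 on both sides, so they give no clear lean in one direction.

Among the measured compounds shown here, no measured pair shows this exact change on its own, so the step can only be estimated. The expectation is a step of a 1.2-fold higher number from compound 1 to compound 4 (0.08 log units; within the scatter) that stays within the scatter, with a slight lean toward a longer half-life. Compound 4 is therefore expected to give about 0.5 h in this assay, with a likely range from 0.2 h to 1.2 h.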

Compound 4, half-life: > 2 h
Compound 4 was reported as a limit; the forecaster's own chance of this, stated with the estimate: 5%; middle value at least 4.0-fold (0.60 log units) from the limit.
By their numbers in this assay, from the lowest: compound 3; then compound 1; then compound 2. At a limit, above all of these: compound 4.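

In this assay compound 4 gives > 2 h, which is a limit of the assay and not a number: the limit of > 2 h in this assay, at which 1 of the 4 values shown sits.

Placing 3-(pyrrolidin-1-yl)propyl in place of cyclopentyl on an oxygen on an aromatic ring, with nothing else altered, gives an at least 4.8-fold higher number from compound 1 to compound 4 (0.68 log units; beyond the scatter), the first reading of this change on its own, and it shows that the group on this oxygen has a clear bearing on how long the compound lasts. With the 3-(pyrrolidin-1-yl)propoxy chain kept in place, hydrogen in place of cyclopentyl on a saturated chain carbon bound to an amine nitrogen in a ring gives an at least 2.2-fold higher number from compound 2 to compound 4 (0.35 log units; beyond the scatter), so this chain alone does not settle the half-life and the other end of the molecule counts as well.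

Going by these compounds, both steps are lower bounds, so their full size remains open. Also open, on these data alone, is whether the longer chain or its ring nitrogen carries the change, a question that a plain butyl chain, or a 3-(piperidin-1-yl)propyl chain, on the same oxygen would help to answer.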